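A few compounds are considered here, and "the series" means these few. Any claim that something is new, unique, unknown or untested is made for them only; others in the source may bear on it.

Series notes on metabolic stability. Compound 1 `CCC/N=C1\S/C(=C\c2ccc(OC(C)=O)c(C)c2)C(=O)N1c1ccccc1C` is the reference point; in an ADME assay on S9 fraction from S9 cells (Zone of skin, Homo sapiens) for metabolic stability, read by HPLC, with a stated time of 180 min, tested at 0.5 uM (on this read-out higher numbers stand for a longer-lived compound and lower numbers for a shorter-lived compound), compound 1 gives 0.122 h. Compound 2 `CCC/N=C1\S/C(=C\c2ccc(OC(=O)CCO)c(C)c2)C(=O)N1c1ccccc1C` differs from it at one place only, and in this assay compound 2 gives 0.137 h. Going by the values given here, the one measured step, a 1.1-fold higher number from compound 1 to compound 2 (0.05 log units; within the scatter), changes nothing beyond the scatter. Among the compounds with values here, compound 1 therefore stands as the lower of the two numbers, with compound 2 its only neighbour and within the scatter of it.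

Compound 3 `CCC/N=C1\S/C(=C\c2ccc(OC(C)=O)c(Br)c2)C(=O)N1c1ccccc1C` is next. Its difference from compound 1 is bromo in place of methyl on an aromatic carbon. Within the data shown here, no measured step touches this aromatic position: the single step from compound 1 to compound 2 alters a saturated chain carbon bound to a carbonyl carbon, not the ring, so it bears on compound 3 only in showing how little the half-life moved on the one change tried. No basis exists for expecting a step beyond the scatter in this assay. The estimate for compound 3 is 0.12 h, expected range 0.06 h to 0.25 h, an expected step of a 1.0-fold lower number from compound 1 to compound 3 (0.01 log units; within the scatter).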

Compound 3, half-life: 0.147 h
Beside the measured number, compound 3's estimate is 1.2-fold (0.09 log units) below it; measured number inside the range.
By their numbers in this assay, from the lowest: compounds 1, 2 and 3 (each within the scatter of the next).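

Going by these compounds alone, the first measured change on the ring, bromo in place of methyl on the aromatic carbon ortho to an acetoxy group, gives a 1.2-fold higher number from compound 1 to compound 3 (0.08 log units; within the scatter) in this assay. The half-life at this position therefore tolerates this exchange within the scatter, so the aromatic carbon, like the saturated chain carbon in the earlier step, has so far shown no step beyond it. Nothing available bears on the reason for this result.

On these data alone, it remains open whether a different group on this aromatic carbon, such as an amine or a carboxylic acid, would give a step beyond the scatter. Also open, as far as these compounds go, is whether bromo in place of methyl reads the same on the ester of compound 2.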